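Swapping nitrile for nitro on a second core

The source may hold more compounds than are shown below. What is called first, only, known or untested is meant among the compounds shown, and "the series" means these compounds.

Of the compounds shown here, three have been measured in a functional assay on LNCaP cells (Homo sapiens) for antiproliferative activity, read by propidium iodide staining, with a stated time of 96 h; on this read-out higher numbers stand for weaker inhibition and lower numbers for stronger inhibition. Compound 1 `CC(O)(COc1cccc(S(F)(F)(F)(F)F)c1)C(=O)Nc1ccc(C#N)cc1C(F)(F)F` gives 9900 nM. Compound 2 `CC(O)(COc1cccc(S(F)(F)(F)(F)F)c1)C(=O)Nc1ccc([N+](=O)[O-])cc1C(F)(F)F` differs from it by nitro in place of cyano on an aromatic carbon and gives 12100 nM, a step of a 1.2-fold higher number from compound 1 to compound 2 (0.09 log units; within the scatter). Compound 3 `CC(O)(CS(=O)(=O)c1ccc(S(F)(F)(F)(F)F)cc1)C(=O)Nc1ccc(C#N)cc1C(F)(F)F` is built on a different core; how the two cores differ is not broken down here. In this assay compound 3 gives 17800 nM, and that number sits within the scatter of both compound 1 and compound 2, so no order among the three can be read.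

Compound 4 `CC(O)(CS(=O)(=O)c1ccc(S(F)(F)(F)(F)F)cc1)C(=O)Nc1ccc([N+](=O)[O-])cc1C(F)(F)F` is not yet measured. It differs from compound 3 by nitro in place of cyano on an aromatic carbon, the same change that turns compound 1 into compound 2, in the same place. Because that change gave a 1.2-fold higher number from compound 1 to compound 2 (0.09 log units; within the scatter), the expected step from compound 3 to compound 4 is similar, namely a 1.2-fold higher number from compound 3 to compound 4 (0.07 log units; within the scatter). Compound 4 is therefore estimated at 21000 nM, within a range from 10000 nM to 45000 nM, resting on a single earlier example of the change.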

Compound 4, half-maximal inhibitory concentration: 12500 nM
The estimate for compound 4 lay 1.7-fold (0.23 log units) above the measured number, and the stated range covers the measured number.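

In this assay, nitro in place of cyano on the core of compound 3 gives a 1.4-fold lower number from compound 3 to compound 4 (0.15 log units; within the scatter), so on this core, as on the core of compound 1, the swap leaves a step no larger than repeat measurements would produce. Set side by side, the two steps do not differ, and the change carries from one core to the other without a readable shift: the same change on two cores in this assay, a 1.2-fold higher number (0.09 log units; within the scatter) from compound 1 to compound 2 and a 1.4-fold lower number (0.15 log units; within the scatter) from compound 3 to compound 4, 1.7-fold (0.24 log units) apart, within the scatter of two such steps. This shows only that nitrile and nitro could not be told apart on these two cores in this one assay; with just two pairs, it does not show that they are equivalent on other cores, and it cannot exclude a small real effect hidden in the scatter.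

The compounds shown leave open how a carboxylic acid or an amine would read on that same aromatic carbon, on either core. They also leave open whether the swap would stay this small on a third core, for instance one with a longer chain.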